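Oxime ether variation on the aminopyrimidine ether series

The compounds below may be only part of what the source reports. "The series", "measured", "known", "first", "only" and "open" are said of these compounds alone.

Measured compounds:
- compound 1 `CO/N=C/c1c(N)ncnc1Oc1ccc2cccnc2c1`: 1820 nM
- compound 2 `Cc1cc2c(F)c(Oc3ncnc(N)c3/C=N/OCCCO)ccc2[nH]1`: 362 nM
- compound 3 `CO/N=C/c1c(N)ncnc1Oc1ccc2[nH]ccc2c1F`: 401 nM

All three numbers come from a functional assay on HeLa cells (Homo sapiens) for antiproliferative activity; on this read-out higher numbers stand for weaker inhibition and lower numbers for stronger inhibition. Compound 2 has the lowest number of the three. Compound 3 stands within the scatter of it, so no order between compound 2 and compound 3 can be read from these values. Compound 1 stands well beyond the scatter, with the higher number. Among the measured compounds shown here, no pair of measured compounds differs in one place only, so no single change has a measured step attached to it.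

Compound 4 `C=CCO/N=C/c1c(N)ncnc1Oc1ccc2[nH]c(C)cc2c1F` is not yet measured in this assay. It differs from compound 2 in one place: vinyl in place of 2-hydroxyethyl on a saturated chain carbon bound to an oxygen. For the measured compounds named here, the oxime ether chain is the only thing that changes; the rest of compound 2 is kept.

Going by the values given here, the data give no step for this kind of change. Compound 2 and compound 3 carry different oxime ether chains and different substitution on the core, yet their values sit within the scatter, which offers no sign that the chain on the oxime oxygen moves the number much. On that basis the step from compound 2 to compound 4 is expected to be small, in neither direction beyond the scatter, a 1.1-fold higher number from compound 2 to compound 4 (0.04 log units; within the scatter). Compound 4 is therefore estimated at 400 nM, with a range from 150 nM to 1100 nM.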

Compound 4, half-maximal inhibitory concentration: 42 nM
The estimate for compound 4 lay 9.5-fold (0.98 log units) above the measured number, and the stated range ends above it.
By their numbers in this assay, from the lowest: compound 4; then compounds 2 and 3 (each within the scatter of the next); then compound 1.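

In this assay, among the compounds shown here, vinyl in place of 2-hydroxyethyl on a saturated chain carbon bound to an oxygen gives an 8.6-fold lower number from compound 2 to compound 4 (0.94 log units; beyond the scatter), the first single-place step, and it shows that the oxime ether chain can move the number beyond the scatter when the rest of compound 2 is kept. The two chains differ in several counted features at once: the 3-hydroxypropyl chain that leaves carries a hydroxyl, while the allyl chain that enters carries a double bond outside aromatic rings and no hydrogen-bond donor or acceptor, so this one pair cannot assign the step to any of these features. No measurement available here speaks to the origin of the step.

Open, as far as these compounds go, is whether the lower number follows the loss of the hydroxyl or the presence of the double bond, a question that a saturated propyl chain, a 3-methoxypropyl chain or a 3-aminopropyl chain on the same core would address. Also open, from the compounds shown here alone, is whether the allyl chain gives a step of similar size on the cores of compound 1 and compound 3.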